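This account rests on a few compounds, and the source may have more. Where it says the series, first, only, none or still open, it means among the compounds named here.

Measured so far in a functional assay (strain AB) with Danio rerio as the target, read by microscopy, with a stated time of 1 h; a higher number here means that more compound is needed for the effect, a lower number that less compound is needed:

- compound 1 `CCN1CCc2c(sc(NC=O)c2C(N)=O)C1`: > 25000 nM, a limit
- compound 2 `CCN1CCc2c(sc(NC(=O)C3(c4ccc(Cl)cc4)CC3)c2C(N)=O)C1`: > 25000 nM, a limit
- compound 3 `CC1CCc2nc(NC(=O)Nc3ccc(Cl)cc3)sc2C1`: > 25000 nM, a limit

Compound 1 gives no number in this assay: its > 25000 nM is a limit of the assay. Compound 2 and compound 3 stand at a limit as well. Among the measured compounds shown here, the whole set therefore comes down to the limit of > 25000 nM in this assay, at which 3 of the 3 values shown sit, and no compound yet gives a half-maximal effective concentration that can serve as a reference point. For the measured compounds named here, no step between measured compounds is available to set a scale for the next change.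

The next compound is compound 4 `CCN1CCc2c(sc(NC(=O)CN3CCCCC3)c2C(N)=O)C1`. It carries (piperidin-1-yl)methyl in place of hydrogen on a carbonyl carbon, whose other neighbour is the amide-type nitrogen of compound 1 ((piperidin-1-yl)methyl in place of hydrogen on a carbonyl carbon).

With nothing but limits to go on, no step beyond the scatter is expected in this assay, and a further limit is the likeliest report. A measurable number, if one appears, would be expected to lie close to the top of the range the assay reports. The estimated change is a number no higher from compound 1 to compound 4 (the limit leaves the size open). This expectation rests only on (the limit of > 25000 nM in this assay, at which 3 of the 3 values shown sit), so the range is kept wide, mainly on the side of lower values.

For compound 4 the expected value is 25000 nM, with an estimated range of 6000 nM to 50000 nM.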

Compound 4, half-maximal effective concentration: > 25000 nM
Compound 4: no number, only a limit; the forecaster's own chance of this, stated with the estimate: 70%; the middle value sits exactly at the limit.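

In this assay compound 4 gives > 25000 nM, which is a limit and not a number. Compound 1 also stands at a limit, so no step can be read between compound 1 and compound 4. The compounds shown leave open whether any change to the shared core yields a measurable half-maximal effective concentration: the limit of > 25000 nM in this assay, at which 4 of the 4 values shown sit.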